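Hydroxy in place of chloro on the shared core

A few compounds are considered here, and "the series" means these few. Any claim that something is new, unique, unknown or untested is made for them only; others in the source may bear on it.

In a functional assay on MOLT-4 cells (Homo sapiens) (on this read-out higher numbers stand for weaker inhibition and lower numbers for stronger inhibition), compound 2 `OC[C@H]1C[C@@H](Cn2cnc3c(Cl)ncnc32)c2ccccc21` gives 24 ug/mL, the higher of the two numbers, while compound 1 `Cc1ccc(-c2ncnc3c2ncn3C[C@@H]2C[C@H](CO)c3ccccc32)cc1` gives 1.4 ug/mL. Compound 3 `OC[C@H]1C[C@@H](Cn2cnc3c(O)ncnc32)c2ccccc21` differs from compound 2 by hydroxy in place of chloro on an aromatic carbon. Among the compounds with values here, the only measured step, a 17-fold higher number from compound 1 to compound 2 (1.23 log units; beyond the scatter), is large, but it exchanges 4-methylphenyl for chloro, so it offers only indirect guidance on this change. A modest move toward weaker inhibition is therefore expected, a 1.7-fold higher number from compound 2 to compound 3 (0.22 log units; within the scatter). The estimated value for compound 3 is 40 ug/mL, with an expected range of 14 ug/mL to 110 ug/mL.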

Compound 3, half-maximal inhibitory concentration: 24 ug/mL
Beside the measured number, compound 3's estimate is 1.7-fold (0.22 log units) above it, and the stated range covers the measured number.
By their numbers in this assay, from the lowest: compound 1; then compounds 2 and 3 (each within the scatter of the next).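

In this assay, hydroxy in place of chloro on this aromatic carbon gives no change at the digits printed from compound 2 to compound 3 (within the scatter), so the added hydrogen-bond donor and acceptor leave the number unmoved. Hydroxy in place of 4-methylphenyl gives a 17-fold higher number from compound 1 to compound 3 (1.23 log units; beyond the scatter), which shows that the loss seen with chloro is not specific to chloro: both one-heavy-atom groups stand apart from 4-methylphenyl. The data at hand offer no explanation for either result. From the compounds shown here alone, whether an amine, a methoxy group or an unsubstituted phenyl on this carbon would stay with chloro and hydroxy or move toward 4-methylphenyl remains open.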